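Morpholine for thiomorpholine on a fluorinated pyridyl thiosemicarbazide

The compounds below may be only part of what the source reports. "The series", "measured", "known", "first", "only" and "open" are said of these compounds alone.

Of the compounds shown here, three of a shared core have been measured in a functional assay on HeLa cells (Homo sapiens) for cytotoxicity, read by MTT assay, with a stated time of 72 h, tested at 10 uM; a lower number here means less inhibition of growth, a higher number more inhibition of growth at the concentration tested. Compound 1 `N/C(=N\NC(=S)N1CCOCC1)c1ccccn1` gives 56.3%, and compound 2 `N/C(=N\NC(=S)N1CCSCC1)c1ccccn1` gives 54.5%; the two differ only in morpholin-4-yl in place of thiomorpholin-4-yl on a thiocarbonyl carbon, and the step of a number 1.8 percentage points higher from compound 2 to compound 1 (within the scatter) lies within the scatter. Compound 3 `N/C(=N\NC(=S)N1CCSCC1)c1ccc(F)cn1` gives 70.5%; it differs from compound 2 by fluoro in place of hydrogen on an aromatic carbon, and the step of a number 16 percentage points higher from compound 2 to compound 3 (beyond the scatter) is beyond the scatter, so compound 3 stands highest of the three.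

Compound 4 `N/C(=N\NC(=S)N1CCOCC1)c1ccc(F)cn1` has not yet been measured. It differs from compound 3 by morpholin-4-yl in place of thiomorpholin-4-yl on a thiocarbonyl carbon, the same change as from compound 2 to compound 1, at the same place. The change is expected to make a small step, a number 1.5 percentage points higher from compound 3 to compound 4 (within the scatter), much like the measured step of a number 1.8 percentage points higher from compound 2 to compound 1 (within the scatter), since nothing in the three measured compounds suggests that the fluoro substituent alters the effect of this exchange. Compound 4 is therefore estimated to give 72% in this assay, with a plausible range from 60% to 83%.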

Compound 4, percent growth inhibition at one concentration: 81.9%
The estimate for compound 4 lay 9.9 percentage points below the measured number; the measured number falls inside the stated range.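

Morpholin-4-yl in place of thiomorpholin-4-yl, carried over to the fluoro-bearing core, gives in this assay a number 11.4 percentage points higher from compound 3 to compound 4 (beyond the scatter), and the two steps of this exchange do not differ by more than the scatter allows: the same change on two cores in this assay, a number 1.8 percentage points higher (within the scatter) from compound 2 to compound 1 and a number 11.4 percentage points higher (beyond the scatter) from compound 3 to compound 4, 9.6 percentage points apart, within the scatter of two such steps

Fluoro in place of hydrogen gives a number 25.6 percentage points higher from compound 1 to compound 4 (beyond the scatter), and this change also carries over between the two cores: the same change on two cores in this assay, a number 16 percentage points higher (beyond the scatter) from compound 2 to compound 3 and a number 25.6 percentage points higher (beyond the scatter) from compound 1 to compound 4, 9.6 percentage points apart, within the scatter of two such steps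

So both changes are consistent with a step of similar size on either core, but the exchange of the two rings passes the scatter on only one of them, and a single pair of cores cannot show that morpholin-4-yl generally gives the higher number or that the two changes truly add up.

The compounds shown leave open whether the same holds with chloro in place of fluoro, or with piperidin-1-yl or piperazin-1-yl on the thiocarbonyl carbon. They also leave open how these steps would look at other concentrations or in other cell lines.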